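A Second Chloro on the Aryl Ring of Compound 1

A few compounds are considered here, and "the series" means these few. Any claim that something is new, unique, unknown or untested is made for them only; others in the source may bear on it.

Measured so far:
compound 1, `CC1(C)C(=O)N(c2cccc(Cl)c2)c2ncccc21`: 49%
compound 2, `Cc1c(Cl)cccc1N1C(=O)C(C)(C)c2cccnc21`: 0%

Compound 1 stands highest of the two in a functional assay on the whole organism (Pleural cavity) for inhibition, with Rattus norvegicus as the target, at a dose of 25 mg/kg; on this read-out lower numbers stand for less inhibition and higher numbers for more inhibition at the one dose given (going by the name of the read-out); compound 2 sits well below it, a large step, a number 49 percentage points lower from compound 1 to compound 2 (beyond the scatter). Compound 3, `CC1(C)C(=O)N(c2cc(Cl)cc(Cl)c2)c2ncccc21`, has not yet been measured. It differs from compound 1 by chloro in place of hydrogen on an aromatic carbon. For the measured compounds named here, no measured step concerns a chloro entering; the single known step, a number 49 percentage points lower from compound 1 to compound 2 (beyond the scatter), concerns a methyl and so bears only loosely on this change. Accordingly the change is expected to be small, within the scatter, a number 7 percentage points lower from compound 1 to compound 3 (within the scatter). Compound 3 is estimated to give 42%, with a range from 10% to 70%.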

Compound 3, a percentage reported as inhibition, in the whole organism at one dose (the size of the read-out at that dose, not a potency): 33%
For compound 3 the middle estimate is 9 percentage points above the measured one, within the range that was stated.
By their numbers in this assay, from the lowest: compound 2; then compound 3; then compound 1.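

For the compounds shown here, the earlier step concerned a methyl, whereas this is the first reading of a chloro entering the ring. In this assay, placing this second chloro on the aromatic carbon meta to the existing chloro group gives a number 16 percentage points lower from compound 1 to compound 3 (beyond the scatter), so hydrogen and chloro are not interchangeable at this position. No measurement available gives a reason for this loss.

From the compounds shown here alone, whether the loss belongs to chloro alone or would follow any group placed here stays open. A fluoro, a methoxy or an amine at this position could answer that.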